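Bis(trifluoromethyl)benzenesulfonamide series: aryl tail variation

The source may hold more compounds than are shown below. What is called first, only, known or untested is meant among the compounds shown, and "the series" means these compounds.

Measured so far:
compound 1 `O=S(=O)(NCCCNCc1ccc(Br)cc1)c1cc(C(F)(F)F)cc(C(F)(F)F)c1` 2700 nM
compound 2 `O=S(=O)(NCCCNCc1ccc(-c2ccccc2)cc1)c1cc(C(F)(F)F)cc(C(F)(F)F)c1` 2600 nM

Both compounds share the same sulfonamide core and differ only in the group on the benzylamine ring. In a functional assay on BE(2)-C cells (Homo sapiens) for inhibition, read by MTT assay, with a stated time of 72 h (on this read-out lower numbers stand for stronger inhibition of growth and higher numbers for weaker inhibition of growth), compound 1 gives 2700 nM and compound 2 gives 2600 nM. Going by the values given here, the single step, a 1.0-fold lower number from compound 1 to compound 2 (0.02 log units; within the scatter), shows that replacing the bromo by a phenyl leaves the number unchanged; compound 2 therefore stands level with compound 1, with no separation beyond the scatter between them.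

Compound 3 `COc1ccc(CNCCCNS(=O)(=O)c2cc(C(F)(F)F)cc(C(F)(F)F)c2)cc1` is the next change: methoxy in place of phenyl on an aromatic carbon. Among the compounds with values here, the only step that bears on it is the one from compound 1 to compound 2, which exchanged one group at the same place and was flat. Within the data shown here, the methoxy is a smaller group than the phenyl and carries one hydrogen-bond acceptor, but the data give no step that tracks either feature. On that basis no change beyond the scatter is expected in this assay, with the step from compound 2 to compound 3 estimated at a 1.0-fold higher number from compound 2 to compound 3 (0.02 log units; within the scatter).

Compound 3 is therefore expected to give about 2700 nM in this assay, within the range 1200 nM to 6500 nM.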

Compound 3, concentration for 50% growth inhibition: 2800 nM
Compound 3: the middle estimate sits 1.0-fold (0.02 log units) below what was measured, and the stated range covers the measured number.
By their numbers in this assay, from the lowest: compounds 2, 1 and 3 (each within the scatter of the next).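

Methoxy in place of phenyl on this aromatic carbon, para to a large group, takes away a six-membered aromatic ring and brings in oxygen with a hydrogen-bond acceptor, yet in this assay it gives a 1.1-fold higher number from compound 2 to compound 3 (0.03 log units; within the scatter) and methoxy in place of bromo gives a 1.0-fold higher number from compound 1 to compound 3 (0.02 log units; within the scatter) with both steps inside the scatter. The earlier pair compared only bromo and phenyl, neither of which carries a hydrogen-bond acceptor, so the three compounds now show that a drop from 6 heavy atoms to 2 and the addition of an acceptor at this place leave this assay without any separation among compound 1, compound 2 and compound 3. No measurement in hand says why this place is so flat in this read-out.

Still open, from the compounds shown here alone, is whether a group of another kind at this place, such as an amine or a carboxylic acid, would separate from these three compounds in this assay. Going by these compounds, all three also share the same chain and the same core, so the effect of a longer chain between the sulfonamide and the benzylamine remains unknown in this set.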